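The compounds below may be only part of what the source reports. "The series", "measured", "known", "first", "only" and "open" are said of these compounds alone.

Working notes on the series.

Compound 1 `Fc1ccccc1Cn1nc(-c2ncc(F)c(N3CCC(F)(F)CC3)n2)cc1-c1ccon1` and compound 2 `OC1CCCN(c2nc(-c3cc(-c4ccon4)n(Cc4ccccc4F)n3)ncc2F)C1` share one core and differ only in the group on the aromatic carbon. In an assay on a protein complex for activation of soluble guanylate cyclase (Homo sapiens), read by cGMP accumulation, in the presence of a further agent that is not named here (a higher number here means that more compound is needed for the effect, a lower number that less compound is needed), compound 1 gives 250 nM, and in the same assay compound 2 gives 33 nM. Going by the values given here, the one measured step is a 7.6-fold lower number from compound 1 to compound 2 (0.88 log units; beyond the scatter), so compound 2 stands at the lowest of the two numbers recorded, with compound 1 the only neighbour.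

Compound 3 `Fc1ccccc1Cn1nc(-c2ncc(F)c(N3CCNCC3)n2)cc1-c1ccon1` is the next member. The change from compound 2 is piperazin-1-yl in place of 3-hydroxypiperidin-1-yl on an aromatic carbon, at the place on the six-membered aromatic ring with 2 nitrogen, ortho to a fluoro group.

Among the compounds with values here, the single measured step bears only loosely on this change: it links two groups on the same carbon, and the ring with 2 hetero atoms has no precedent here. Within the data shown here, no step for an exchange of this kind is available, so the expectation is anchored on compound 2 alone. A small shift toward a higher number is estimated, a 1.8-fold higher number from compound 2 to compound 3 (0.26 log units; within the scatter), well within broad limits. Compound 3 is therefore expected to give about 60 nM in this assay, with a range from 15 nM to 250 nM.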

Compound 3, half-maximal effective concentration: 120 nM
Estimate against measurement, compound 3: 2.0-fold (0.30 log units) below; the measured number falls inside the stated range.
By their numbers in this assay, from the lowest: compound 2; then compound 3; then compound 1.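

In this assay, the position on the aromatic carbon opposite the ring nitrogen now holds three groups, and piperazin-1-yl falls in the middle: the numbers show a 3.6-fold higher number from compound 2 to compound 3 (0.56 log units; beyond the scatter) in one direction and a 2.1-fold lower number from compound 1 to compound 3 (0.32 log units; beyond the scatter) in the other, both beyond the scatter. No exchange of a ring with 2 hetero atoms had been seen before. Going by these compounds alone, this is the first sign that such a ring is accepted here, though with a higher number than 3-hydroxypiperidin-1-yl despite the same counts of hydrogen-bond donors and acceptors. Nothing available explains this order.

The compounds shown leave open where morpholin-4-yl or an open-chain amine such as dimethylamino would fall. They also leave open whether moving the hydroxyl group, as in 4-hydroxypiperidin-1-yl, would change the number.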